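Solubility notes: aromatic isopropoxy on the compound 2 core

This account rests on a few compounds, and the source may have more. Where it says the series, first, only, none or still open, it means among the compounds named here.

Compound 2 `CN(C)CCNc1n[n+]([O-])c2ccccc2[n+]1[O-]` gives 50000000 nM in a physicochemical assay for solubility, in the presence of a further agent that is not named here (a lower number here means a less soluble compound, a higher number a more soluble compound), the lowest of the two plain numbers shown. Compound 1 `[O-][n+]1nc(NCCn2cccc2)[n+]([O-])c2ccccc21` gives 61000000 nM in this assay; the step of a 1.2-fold lower number from compound 1 to compound 2 (0.09 log units; within the scatter) is within the scatter. For compound 3 `CCCN(CCC)CCNc1n[n+]([O-])c2ccccc2[n+]1[O-]` this assay reports only a limit, > 25000000 nM, noted as the limit of > 25000000 nM in this assay, at which 1 of the 3 values shown sits. The steps a step that the limit leaves unreadable from compound 1 to compound 3 and a step that the limit leaves unreadable from compound 2 to compound 3 are therefore not readable. Going by the values given here, compound 4 `CC(C)Oc1ccc2c(c1)[n+]([O-])c(NCCN(C)C)n[n+]2[O-]` carries isopropoxy in place of hydrogen on an aromatic carbon; all measured steps alter the amine on the chain, none touches the aromatic ring, so no measured step bears directly on this change. The expected step of a 2.5-fold lower number from compound 2 to compound 4 (0.40 log units; beyond the scatter) is a modest fall, with a wide range. Compound 4 is estimated at 20000000 nM in this assay, between 5000000 nM and 60000000 nM.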

Compound 4, solubility: > 51000000 nM
Compound 4: no number, only a limit; the forecaster's own chance of this, stated with the estimate: 30%; middle value at least 2.5-fold (0.40 log units) away from the limit.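

In this assay compound 4 reports only a limit, > 51000000 nM. Isopropoxy in place of hydrogen on an aromatic carbon, the only change shown away from the chain amine, gives an at least 1.0-fold higher number from compound 2 to compound 4 (0.00 log units; that floor lies within the scatter), a floor that excludes a fall but does not establish a rise. The earlier steps said nothing about the aromatic ring; this one shows that the read-out does not fall with isopropoxy there: the limit of > 51000000 nM in this assay, at which 1 of the 4 values shown sits.

The true size of this step cannot be read, nor can the steps to compound 3. From the compounds shown here alone, whether an amine or a carboxylic acid on that aromatic carbon would behave the same stays open.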